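Moving the trifluoromethyl group: from compound 3 to compound 4

A few compounds are considered here, and "the series" means these few. Any claim that something is new, unique, unknown or untested is made for them only; others in the source may bear on it.

Measured so far in an assay on microsomes for inhibition of acyl-CoA:cholesterol acyltransferase (Oryctolagus cuniculus); on this read-out higher numbers stand for weaker inhibition and lower numbers for stronger inhibition:
compound 1, `Cc1ccccc1C1(CNC(=O)Nc2c(C(C)C)cccc2C(C)C)CCCC1`: 17 nM
compound 2, `CC(C)c1ccc(C2(CNC(=O)Nc3c(C(C)C)cccc3C(C)C)CCCC2)cc1`: 48 nM
compound 3, `CC(C)c1cccc(C(C)C)c1NC(=O)NCC1(c2ccccc2C(F)(F)F)CCCC1`: 18 nM

Compound 3 stands second highest of the three numbers. Against compound 1 the difference is a 1.1-fold higher number from compound 1 to compound 3 (0.02 log units; within the scatter), within the scatter; against compound 2 it is a 2.7-fold lower number from compound 2 to compound 3 (0.43 log units; beyond the scatter), beyond it.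

Compound 4, `CC(C)c1cccc(C(C)C)c1NC(=O)NCC1(c2ccc(C(F)(F)F)cc2)CCCC1`, differs from compound 3 by 4-(trifluoromethyl)phenyl in place of 2-(trifluoromethyl)phenyl on a saturated ring carbon. Among the measured compounds shown here, the only measured step that bears on a change of this kind is a 2.8-fold higher number from compound 1 to compound 2 (0.45 log units; beyond the scatter), where 2-methylphenyl gave way to 4-isopropylphenyl; that step also changed the group itself, so it is an imperfect guide. A modest rise is therefore expected, a 1.9-fold higher number from compound 3 to compound 4 (0.29 log units; within the scatter). Compound 4 is estimated at 35 nM, in a range of 14 nM to 90 nM.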

Compound 4, half-maximal inhibitory concentration: 66 nM
Compound 4: middle estimate off by 1.9-fold (0.28 log units), on the low side, and the stated range covers the measured number.
By their numbers in this assay, from the lowest: compounds 1 and 3 (each within the scatter of the next); then compounds 2 and 4 (each within the scatter of the next).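

In this assay the same atoms joined differently are enough to weaken inhibition, with 4-(trifluoromethyl)phenyl in place of 2-(trifluoromethyl)phenyl giving a 3.7-fold higher number from compound 3 to compound 4 (0.56 log units; beyond the scatter) and the change from 2-methylphenyl giving a 3.9-fold higher number from compound 1 to compound 4 (0.59 log units; beyond the scatter) on the same saturated ring carbon. Trifluoromethyl in place of isopropyl gives only a 1.4-fold higher number from compound 2 to compound 4 (0.14 log units; within the scatter) so across these four compounds the number follows where the group sits on the phenyl rather than which group it is, and none of them goes against this. Nothing measured here accounts for the difference.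

From the compounds shown here alone, whether 2-methoxyphenyl or 2-chlorophenyl would stay with the lower numbers remains open. So does whether an amine on the phenyl would fit the same pattern.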